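This account rests on a few compounds, and the source may have more. Where it says the series, first, only, none or still open, it means among the compounds named here.

Measured compounds:
- compound 1 `Cc1cc(C(=O)Nc2ccccc2)nn1Cc1cc(Cl)ccc1OCc1ccccc1` — no result in an in vivo ADME assay on the whole organism for pharmacokinetics, with Rattus norvegicus as the target; on this read-out lower numbers stand for narrower distribution and higher numbers for wider distribution into tissues ("not determined" (no result reported))
- compound 2 `Cc1cc(NC(=O)C2CCOCC2)nn1Cc1cc(Cl)ccc1OCc1ccccc1` — 3.3 L/kg
- compound 3 `Cc1cc(NC(=O)C2CCCCC2)nn1Cc1cc(Cl)ccc1OCC(C)C` — 3.5 L/kg

Compound 2 holds the lower of the two numbers in this assay, but compound 3 sits so close that the two values show no difference beyond the scatter. Compound 1 adds nothing to the comparison, as no number was reported for it. Among the measured compounds shown here, no step between two measured compounds that differ in one place is available, so nothing in the measured set tells how a change at the carbonyl carbon moves the read-out.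

Compound 4 `Cc1cc(NC(=O)OCc2ccccn2)nn1Cc1cc(Cl)ccc1OCc1ccccc1` is the next entry. Relative to compound 2 the change is (pyridin-2-yl)methoxy in place of oxan-4-yl on a carbonyl carbon: the oxan-4-yl group leaves, and (pyridin-2-yl)methoxy enters on the carbonyl carbon whose other neighbour is the amide-type nitrogen, so the amide becomes a carbamate. For the measured compounds named here, with no comparable step in hand, the expected step from compound 2 to compound 4 is set at a 1.1-fold lower number from compound 2 to compound 4 (0.04 log units; within the scatter), that is, no movement beyond the scatter in either direction. On that basis compound 4 is estimated at 3 L/kg in this assay, with a range from 1.5 L/kg to 6 L/kg. The estimate rests on the two measured values only and carries the uncertainty of an untested change.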

Compound 4, volume of distribution at steady state: 3 L/kg
The estimate for compound 4 equals the measured number at the digits printed; the range from low to high includes it.
By their numbers in this assay, from the lowest: compounds 4, 2 and 3 (each within the scatter of the next).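

Among the compounds shown here, this is the first step at this position that can be read: with (pyridin-2-yl)methoxy in place of oxan-4-yl on a carbonyl carbon whose other neighbour is the amide-type nitrogen, this assay shows a 1.1-fold lower number from compound 2 to compound 4 (0.04 log units; within the scatter). The amide thus becomes a carbamate, and the non-aromatic six-membered ring gives way to an aromatic one with 8 heavy atoms in the entering group against 6 in the leaving one, yet this single pair stays unseparated on the read-out, so within this pair neither the carbamate link nor the pyridine ring sets compound 4 apart from compound 2. No information on hand bears on why the two compounds are not separated.

One pair cannot show whether this holds for other groups on the same carbonyl carbon, for example a carboxylic acid or a dimethylamino group, and a group of that kind would test how far the read-out stays unmoved at this position. Going by these compounds, it also remains open whether the same replacement gives a similar step when the rest of the molecule carries a different ether group on the shared core.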